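Trimethoxyanilides: nitro to fluoro on the benzamide

A few compounds are considered here, and "the series" means these few. Any claim that something is new, unique, unknown or untested is made for them only; others in the source may bear on it.

Working notes on a small anilide series built around a trimethoxyphenyl amine. Compound 1 `COc1cc(NC(=O)Nc2ccccc2)cc(OC)c1OC` is the urea; in a functional assay on Daoy cells (Homo sapiens) for cytotoxicity, read by MTT assay, with a stated time of 72 h (on this read-out lower numbers stand for stronger inhibition and higher numbers for weaker inhibition), compound 1 carries the entry "not determined" (no result reported), so it contributes no number here. For the measured compounds named here, compound 2 `COc1cc(NC(=O)c2ccc([N+](=O)[O-])cc2)cc(OC)c1OC` is the nitrobenzamide; in this assay compound 2 gives 52900 nM, the only value in the set, and it marks weak cytotoxicity. Compound 3 `COc1cc(NC(=O)c2ccc(F)cc2)cc(OC)c1OC` is the next analogue, not yet measured in this assay. The change from compound 2 to compound 3 is fluoro in place of nitro on an aromatic carbon; in words, fluoro in place of nitro on an aromatic carbon. No step between measured compounds exists, so nothing shown says how large this kind of exchange turns out in this assay. The expectation for compound 3 is a step of a 1.2-fold higher number from compound 2 to compound 3 (0.09 log units; within the scatter), within the usual scatter or at most slightly weaker. Compound 3 is therefore estimated at 65000 nM, with a range from 20000 nM to 200000 nM in this assay.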

Compound 3, half-maximal inhibitory concentration: >= 125000 nM
Compound 3 ended at the assay's limit; the forecaster's own chance of this, stated with the estimate: 30%; at least 1.9-fold (0.28 log units) between middle value and limit.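

Fluoro in place of nitro on this aromatic carbon gives the series its first readable step in this assay: an at least 2.3-fold higher number from compound 2 to compound 3 (0.37 log units; beyond the scatter). The position is therefore not indifferent to this exchange, since the change lies beyond the scatter and compound 2 holds the lower number. Compound 3 gives >= 125000 nM, which is a limit of the assay and not a number, so the step has a floor but no upper end: the limit of >= 125000 nM in this assay, at which 1 of the 3 values shown sits.

From the compounds shown here alone, it stays open whether the lower number of compound 2 is particular to nitro, or whether an amine, a nitrile or a carboxylic acid on the same carbon would fall nearer to compound 2 or to compound 3. Steps to compound 1 cannot be read.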